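Working notes on a urea series: adding (methylsulfonyl)methyl

The source may report more compounds than this note shows. Statements on the series, on what has been measured and on what is new or still open speak of the compounds shown alone.

Measured compounds in a physicochemical assay for lipophilicity; a lower number here means a more polar compound, a higher number a more lipophilic compound:
- compound 1 `CCNC(=O)Nc1ccc(-c2nccc(C3=CCOCC3)n2)cc1` gives 3.6
- compound 2 `CCNC(=O)Nc1ccc(-c2nccc([C@@]34CCOC[C@@H]3C4)n2)cc1` gives 3.9
- compound 3 `CCNC(=O)Nc1ccc(-c2nccc([C@]34CCOC[C@H]3C4)n2)cc1` gives 3.9

Compound 2 stands level with compound 3 at the digits printed, and the two share the highest number of the three. The steps seen so far are small: a number 0.30 log units higher from compound 1 to compound 2 (within the scatter) and a number 0.30 log units higher from compound 1 to compound 3 (within the scatter), both within the scatter, and no change at the digits printed from compound 2 to compound 3 (within the scatter), which follows from the fact that compounds 2 and 3 differ only in the configuration as drawn.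

Compound 4 `CCNC(=O)Nc1ccc(-c2nc(CS(C)(=O)=O)cc([C@@]34CCOC[C@@H]3C4)n2)cc1` is not yet measured in this assay. It differs from compound 2 as follows: (methylsulfonyl)methyl in place of hydrogen on an aromatic carbon. Within the data shown here, none of the measured steps adds a group of this kind; they exchange one saturated ring system for another or invert configuration, so they give no direct guide to this change. Compound 4 is therefore expected to give 2.7 in this assay, between 2.1 and 3.3. Against compound 2 this would be an expected step of a number 1.20 log units lower from compound 2 to compound 4 (beyond the scatter).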

Compound 4, partition coefficient: 3.6
For compound 4 the middle estimate is 0.90 log units below the measured one, outside the stated range (above it).
By their numbers in this assay, from the lowest: compounds 1, 4, 2 and 3 (each within the scatter of the next).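

In this assay, the step for (methylsulfonyl)methyl in place of hydrogen on this aromatic carbon, next to the ring nitrogen, is a number 0.30 log units lower from compound 2 to compound 4 (within the scatter). This is the first change shown at this position of the shared core, as the earlier compounds vary only the saturated ring system or its configuration, and here a group with 2 hydrogen-bond acceptors leaves compound 4 within the scatter of compound 2. Nothing measured among these compounds accounts for this result.

Still open, on these data alone, is whether an amine or a carboxylic acid on the same aromatic carbon would give a step beyond the scatter in this assay. Also open, as far as these compounds go, is whether (methylsulfonyl)methyl would give a comparable step on compound 3, the mirror image of compound 2.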